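From Methoxy to Pentyl on a Shared Core

The compounds below may be only part of what the source reports. "The series", "measured", "known", "first", "only" and "open" are said of these compounds alone.

Measured in a functional assay on MDA-MB-231 cells (Homo sapiens) for antiproliferative activity, with a stated time of 4 days; on this read-out higher numbers stand for weaker inhibition and lower numbers for stronger inhibition:
- Compound 1 `COc1ccc(-c2[nH]c3ccc(OC)cc3c2C=C(C#N)C#N)cc1`: 590 nM
- Compound 2 `COc1ccc(-c2[nH]c3cc(F)ccc3c2C=C(C#N)C#N)cc1`: 280 nM

Compound 1 has the higher of the two numbers, which makes it the weaker inhibitor of the pair. Compound 2 sits lower, by a gap just beyond the usual scatter of repeated measurements. Going by the values given here, no measured pair isolates a single change, so the data offer no direct guide to the next step.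

Compound 3 `CCCCCc1ccc2[nH]c(-c3ccc(OC)cc3)c(C=C(C#N)C#N)c2c1` keeps the core of compound 1 and alters one group: pentyl in place of methoxy on an aromatic carbon. In plain terms, this puts pentyl in place of methoxy on an aromatic carbon. Among the compounds with values here, the only anchors are compound 1 at 590 nM and compound 2 at 280 nM, and neither carries a pentyl chain. A small move toward weaker inhibition in this assay is therefore expected, possibly no larger than the scatter, though this is a cautious guess. The expected change is a 1.4-fold higher number from compound 1 to compound 3 (0.13 log units; within the scatter). For compound 3 the estimated value is 800 nM, with an expected range from 200 nM to 3000 nM.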

Compound 3, half-maximal inhibitory concentration: 42 nM
Compound 3: the middle estimate sits 19-fold (1.28 log units) above what was measured; measured number below the stated range.
By their numbers in this assay, from the lowest: compound 3; then compound 2; then compound 1.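

In this assay, going by these compounds alone, putting pentyl in place of methoxy gives a 14-fold lower number from compound 1 to compound 3 (1.15 log units; beyond the scatter) and marks the first single change that can be read in this set, a large step well beyond the scatter. It shows that this aromatic carbon, on the six-membered aromatic ring of carbon only within the fused system, is a place where the choice of group strongly affects the read-out. Here the larger, all-carbon pentyl chain brings stronger inhibition, not the small loss that might have been feared, but nothing available on these compounds accounts for the change, so the step records an outcome without a cause.

A single step cannot separate the length of the chain from the loss of the oxygen, so a butyl or hexyl chain, or a pentyloxy group, at the same carbon would help to tell those two apart. The compounds shown also leave open how far the gain depends on a plain carbon chain, which an amine or a carboxylic acid at the end of that chain would test.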